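Closing the Amine Substituent into a Ring

The source may report more compounds than this note shows. Statements on the series, on what has been measured and on what is new or still open speak of the compounds shown alone.

compound 1, `COc1cc(C(=O)c2sc(N(C)C)nc2N)cc(OC)c1OC`: 11000 nM
compound 2, `CCN(CC)c1nc(N)c(C(=O)c2cc(OC)c(OC)c(OC)c2)s1`: 78000 nM
compound 3, `COc1cc(C(=O)c2sc(N(C)Cc3ccccc3)nc2N)cc(OC)c1OC`: > 200000 nM

These three compounds share one core and differ only in the amine attached to the aromatic carbon, and all were tested in a functional assay on CCRF-CEM cells (Homo sapiens) for antiproliferative activity, read by cell counting, with a stated time of 2 days; a higher number here means a weaker inhibitor, a lower number a stronger inhibitor. Compound 3 gives > 200000 nM in this assay, which is a limit of the assay rather than a number. It is the weakest of the three, with the limit of > 200000 nM in this assay, at which 1 of the 3 values shown sits, and the steps reaching it are an at least 18-fold higher number from compound 1 to compound 3 (1.25 log units; beyond the scatter) and an at least 2.5-fold higher number from compound 2 to compound 3 (0.40 log units; beyond the scatter).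

Compound 4, `COc1cc(C(=O)c2sc(N3CCCCC3)nc2N)cc(OC)c1OC`, has not been measured. The change is piperidin-1-yl in place of benzyl(methyl)amino on an aromatic carbon. Within the data shown here, three measured steps bear on it: a 7.1-fold higher number from compound 1 to compound 2 (0.85 log units; beyond the scatter), so enlarging the alkyl arms costs a modest amount; an at least 18-fold higher number from compound 1 to compound 3 (1.25 log units; beyond the scatter), so adding the phenyl costs much more; and an at least 2.5-fold higher number from compound 2 to compound 3 (0.40 log units; beyond the scatter). Piperidin-1-yl removes the phenyl and resembles diethylamino joined into a ring, so compound 4 is expected to improve on compound 3 by an at least 4.0-fold lower number from compound 3 to compound 4 (0.60 log units; beyond the scatter), landing near compound 2. The estimate for compound 4 is 50000 nM, within 10000 nM to 200000 nM.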

Compound 4, half-maximal inhibitory concentration: 22000 nM
The estimate for compound 4 lay 2.3-fold (0.36 log units) above the measured number, within the range that was stated.
By their numbers in this assay, from the lowest: compounds 1 and 4 (each within the scatter of the next); then compound 2. At a limit, above all of these: compound 3.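

In this assay, closing the two arms of the amine into piperidin-1-yl beats the open diethylamino group, with a 3.5-fold lower number from compound 2 to compound 4 (0.55 log units; beyond the scatter), so at this position, joining the arms into a ring matters and not only the size of the amine. The earlier steps shown here showed only numbers rising as the amine grew from dimethylamino, but the ring goes against that pattern: it cannot be told apart from dimethylamino, with a 2.0-fold higher number from compound 1 to compound 4 (0.30 log units; within the scatter). Replacing benzyl(methyl)amino gives an at least 9.0-fold lower number from compound 3 to compound 4 (0.95 log units; beyond the scatter), and that step starts from a limit for compound 3 rather than a number: the limit of > 200000 nM in this assay, at which 1 of the 4 values shown sits.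

Still open, from the compounds shown here alone, is whether this holds for other rings, such as pyrrolidin-1-yl or morpholin-4-yl. Also open, going by these compounds, is whether a plain amino group on the same carbon would give a lower number than dimethylamino.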